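A few compounds are considered here, and "the series" means these few. Any claim that something is new, unique, unknown or untested is made for them only; others in the source may bear on it.

Three compounds have been measured in a functional assay on HCT-116 cells (Homo sapiens) for antiproliferative activity, read by MTT assay, with a stated time of 48 h; on this read-out lower numbers stand for stronger inhibition and higher numbers for weaker inhibition:

Compound 1 `Cc1ccc2nc(Nc3nc(Nc4ccc(S(N)(=O)=O)cc4)ncc3F)sc2c1` gives 1460 nM.
Compound 2 `Cc1ccc2nc(Nc3nc(Nc4ccc(S(N)(=O)=O)cc4)ncc3C)sc2c1` gives 3870 nM.
Compound 3 `Cc1ccc2nc(Nc3nc(Nc4ccc(S(C)(=O)=O)cc4)ncc3F)sc2c1` gives 9180 nM.

Compound 1 has the lowest number of the three. The nearest to it is a 2.7-fold higher number from compound 1 to compound 2 (0.42 log units; beyond the scatter), the furthest a 6.3-fold higher number from compound 1 to compound 3 (0.80 log units; beyond the scatter). Compound 4 `COc1ccc2nc(Nc3nc(Nc4ccc(S(N)(=O)=O)cc4)ncc3F)sc2c1` differs from compound 1 in one place: methoxy in place of methyl on an aromatic carbon. Neither measured step bears on this change, since one altered the fluoro and the other the sulfonyl group, while the methyl on the fused ring was left untouched in both. There is therefore no guide from the data beyond the fact that single changes elsewhere on this core each gave modest shifts. A step within the scatter, or a modest one in either direction, is expected as a 1.0-fold higher number from compound 1 to compound 4 (0.01 log units; within the scatter). Compound 4 is expected to give 1500 nM, between 600 nM and 4000 nM.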

Compound 4, half-maximal inhibitory concentration: 11500 nM
Compound 4: middle estimate off by 7.7-fold (0.88 log units), on the low side; the measured number lies above the stated range.
By their numbers in this assay, from the lowest: compound 1; then compound 2; then compounds 3 and 4 (each within the scatter of the next).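

Going by these compounds alone, the methyl on the fused ring, untouched by the earlier steps, turns out to matter: methoxy in its place gives a 7.9-fold higher number from compound 1 to compound 4 (0.90 log units; beyond the scatter) in this assay, so inhibition weakens. This carbon therefore does not accept every small group equally. No available evidence accounts for this step.

Going by these compounds, with a single replacement here, it stays open whether the added oxygen or the larger size of the methoxy group goes with the weaker inhibition. An ethyl, a chloro or a hydroxyl group at this carbon would help to separate these possibilities.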